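The source may hold more compounds than are shown below. What is called first, only, known or untested is meant among the compounds shown, and "the series" means these compounds.

The series shares one sugar-bearing core and varies the groups on the fused ring system. Compound 1, `Cc1ncnc2c1c(I)cn2[C@@H]1O[C@H](CO)[C@@H](O)[C@H]1O`, gives in an ADME assay on BJ cells (Homo sapiens), read by MTT assay, with a stated time of 72 h (on this read-out higher numbers stand for weaker inhibition and lower numbers for stronger inhibition), only a limit of the assay, > 100000 nM. Among the compounds with values here, compound 2, `COc1ncnc2c1c(-c1ccoc1)cn2[C@@H]1O[C@H](CO)[C@@H](O)[C@H]1O`, is the one compound with a number in this assay, 28800 nM. Compound 3, `Cc1nc(N)c2c(-c3ccco3)cn([C@@H]3O[C@H](CO)[C@@H](O)[C@H]3O)c2n1`, likewise reaches only the limit, > 100000 nM. Within the data shown here, compound 3 thus stands where two of the three values sit, (the limit of > 100000 nM in this assay, at which 2 of the 3 values shown sit), and no step between measured compounds is recorded, so no measured change can guide the next one.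

Compound 4, `Cc1nc(N)c2c(-c3ccoc3)cn([C@@H]3O[C@H](CO)[C@@H](O)[C@H]3O)c2n1`, is compound 3 rearranged: furan-3-yl in place of furan-2-yl on an aromatic carbon. Compound 3 sits only at the limit of this assay. Compound 2, which also bears furan-3-yl, gives 28800 nM in this assay. On these two points compound 4 is expected to remain weak in this assay. The step of an at least 1.1-fold lower number from compound 3 to compound 4 (0.04 log units; that floor lies within the scatter) is estimated to lie within the usual scatter, with no clear direction. Compound 4 is therefore expected near 90000 nM, between 25000 nM and 300000 nM, and a limit rather than a number is the likelier result.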

Compound 4, half-maximal inhibitory concentration: > 100000 nM
Compound 4: only a limit was reported (the forecaster's own chance of this, stated with the estimate: 60%); at least 1.1-fold (0.04 log units) between middle value and limit.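

Compound 4 gives only a limit in this assay, > 100000 nM, just as compound 3 does, so the step between these two compounds cannot be read. The compounds shown leave open whether furan-3-yl or furan-2-yl goes with stronger inhibition on the shared core.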